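A few compounds are considered here, and "the series" means these few. Any claim that something is new, unique, unknown or untested is made for them only; others in the source may bear on it.

Working notes on the series

Two members of the series have a number in an assay on Prostate gland for inhibition of steroid 5-alpha-reductase (Rattus norvegicus); a higher number here means a weaker inhibitor, a lower number a stronger inhibitor. Compound 1 `CCCCCC(CCCCC)n1ccc2cc(/C(C)=C/C(=O)Nc3ccccc3OCCCC(=O)O)ccc21` gives 25 nM in this assay. Compound 2 `C/C(=C\C(=O)Nc1ccccc1OCCCC(=O)O)c1ccc2c(ccn2Cc2ccc(C)cc2)c1` gives 88 nM in this assay. For the measured compounds named here, the one step between them, a 3.5-fold higher number from compound 1 to compound 2 (0.55 log units; beyond the scatter), concerns the substituent on the aromatic nitrogen and nothing else. Compound 2 therefore stands with the higher of the two numbers, the weaker inhibitor of the pair in this assay.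

Compound 3 `C/C(=C\C(=O)Nc1ccccc1OCCCC(=O)O)c1ccc2c(ccn2Cc2ccc(F)cc2)c1` keeps everything of compound 2 and changes only the end of the benzyl group: fluoro in place of methyl on an aromatic carbon of a six-membered aromatic ring of carbon only. Going by the values given here, no measured step touches this position. Among the compounds with values here, the only step recorded, from compound 1 to compound 2, swaps the whole nitrogen substituent and gives no guide to a single-atom exchange at the far end of the benzyl group. With nothing to point either way, the expectation is a step of no size beyond the scatter, a 1.1-fold higher number from compound 2 to compound 3 (0.06 log units; within the scatter), from compound 2 to compound 3 in this assay. Compound 3 is accordingly estimated at 100 nM in this assay, within a range of 40 nM to 250 nM.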

Compound 3, half-maximal inhibitory concentration: 97 nM
For compound 3 the middle estimate is 1.0-fold (0.01 log units) above the measured one, within the range that was stated.
By their numbers in this assay, from the lowest: compound 1; then compounds 2 and 3 (each within the scatter of the next).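

At the end of the benzyl group, fluoro in place of methyl on an aromatic carbon, para to a large group, gives a 1.1-fold higher number from compound 2 to compound 3 (0.04 log units; within the scatter) in this assay and so shows no change that can be told from the scatter at this position. The step at the aromatic nitrogen looks much the same with the new end group, as a 3.9-fold higher number from compound 1 to compound 3 (0.59 log units; beyond the scatter) stands close to the step recorded for 4-methylbenzyl, and both benzyl compounds lie beyond the scatter on the side of the higher number relative to 1-pentylhexyl. Nothing available explains why the exchange of these two groups leaves the number where it is.

Methyl and fluoro are the only two groups seen at this place, so it remains open whether the position stays as unresponsive with a methoxy group, a trifluoromethyl group, an amine or a plain hydrogen there. The compounds shown also leave open how an unbranched hexyl chain on the aromatic nitrogen would compare with both 1-pentylhexyl and the benzyl groups.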